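The source may hold more compounds than are shown below. What is called first, only, known or untested is meant among the compounds shown, and "the series" means these compounds.

Among the compounds with values here, in a functional assay on MES-SA cells (Homo sapiens) for inhibition, with a stated time of 72 h, in the presence of a further agent that is not named here (a lower number here means a stronger inhibitor, a higher number a weaker inhibitor), three compounds have numbers so far. Compound 1 `Oc1c(CN2CCCCC2)ccc2cccnc12` gives 4180 nM; 4070 nM (2 entries) in its repeated entries, and these lie under the numbers of the other two. Compound 2 `CCOCc1cc(CN2CCCC2)c(O)c2ncccc12` gives 8710 nM in the same read-out. Compound 3 `COCc1cc(CN2CCCCC2)c(O)c2ncccc12` gives 9550 nM and so stands level with compound 2 within the usual scatter, with compound 1 the only one clearly apart on these numbers.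

Compound 4 `CCOCc1cc(CN2CCCCC2)c(O)c2ncccc12` is reached from compound 3 by one small change, methyl in place of hydrogen on a saturated chain carbon bound to an oxygen on a saturated carbon in all. Methyl replaces hydrogen on a saturated chain carbon bound to an oxygen on a saturated carbon, so that methoxymethyl becomes ethoxymethyl.

Within the data shown here, no measured pair isolates this change, so the expectation rests on indirect evidence. Compound 2 already carries the ethoxymethyl group, though it differs from compound 4 elsewhere. In this read-out compound 2 gives 8710 nM and compound 3 gives 9550 nM, and these two numbers cannot be told apart. On that basis no shift beyond the scatter is expected in this assay and no direction can be favoured. The expected change is a 1.1-fold lower number from compound 3 to compound 4 (0.05 log units; within the scatter) and it is estimated to stay within the scatter. For compound 4 the estimate is 8500 nM as a central value. The expected range for compound 4 runs from 4500 nM up to 16000 nM in this estimate.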

Compound 4, half-maximal inhibitory concentration: 9120 nM
The estimate for compound 4 lay 1.1-fold (0.03 log units) below the measured number; low and high end bracket the measured number.
By their numbers in this assay, from the lowest: compounds 2, 4 and 3 (each within the scatter of the next).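

In this assay, within the data shown here, the step from methoxymethyl to ethoxymethyl, a 1.0-fold lower number from compound 3 to compound 4 (0.02 log units; within the scatter), gives the first direct reading at this saturated chain carbon bound to an oxygen, and the added methyl leaves the two numbers level. Among these compounds, compound 4 also gives the first direct reading of the amine ring on the saturated chain carbon bound to an aromatic carbon: piperidin-1-yl in place of pyrrolidin-1-yl, a 1.0-fold higher number from compound 2 to compound 4 (0.02 log units; within the scatter), likewise stays within the scatter, so neither single change separates these compounds in this read-out. The repeated entries of compound 1 show how closely two readings can agree in this assay: the several entries of compound 1 in this assay, 4180 nM; 4070 nM (2 entries)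

On these data alone, both steps are small changes, so it remains open whether a longer chain or a hydroxymethyl group at the ether position would move the number beyond the scatter. As far as these compounds go, it also remains open how a morpholine ring or an open-chain amine such as dimethylamino would read in place of piperidin-1-yl on the saturated chain carbon bound to an aromatic carbon.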